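The source may report more compounds than this note shows. Statements on the series, on what has been measured and on what is new or still open speak of the compounds shown alone.

Measured so far in an assay on SH-SY5Y cells for inhibition of Voltage-dependent N-type calcium channel subunit alpha-1B (Homo sapiens), read by FLIPR and calcium flux, with stated times of 600 s and 300 s, in the presence of a further agent that is not named here; a lower number here means a stronger inhibitor, a higher number a weaker inhibitor:
compound 1 `CN(C)CCCOc1ccc(CN(C)c2nc3ccc(Oc4ccc(C(F)(F)F)cc4)cc3s2)cc1`; compound 1 gives 46000 nM
compound 2 `CN(Cc1ccc(OCCCNC(=N)N)cc1)c1nc2ccc(Oc3ccc(C(F)(F)F)cc3)cc2s1`; compound 2 gives 185000 nM
compound 3 `CN(Cc1ccc(OCCCN)cc1)c1nc2ccc(Oc3ccc(C(F)(F)F)cc3)cc2s1`; compound 3 gives 283000 nM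

Compound 2 holds the second highest of the three numbers: its nearest neighbour is compound 3, a 1.5-fold higher number from compound 2 to compound 3 (0.18 log units; within the scatter), and its furthest is compound 1, a 4.0-fold higher number from compound 1 to compound 2 (0.60 log units; beyond the scatter).

Compound 4 `CN(Cc1ccc(OCCCNC(=N)N)cc1)c1nc2ccc(Oc3ccc(O)cc3)cc2s1` differs from compound 2 in hydroxy in place of trifluoromethyl on an aromatic carbon. Among the measured compounds shown here, none of the measured steps bears on this place: a 4.0-fold higher number from compound 1 to compound 2 (0.60 log units; beyond the scatter), a 6.2-fold higher number from compound 1 to compound 3 (0.79 log units; beyond the scatter) and a 1.5-fold higher number from compound 2 to compound 3 (0.18 log units; within the scatter) all alter the saturated chain end, and the aromatic carbon changed here is untouched in every measured pair. All three numbers in this assay are high, which is the only context available. For the measured compounds named here, with no precedent, the step is expected to be a 1.6-fold higher number from compound 2 to compound 4 (0.21 log units; within the scatter), with wide uncertainty in either direction. Compound 4 is estimated at 300000 nM, range 90000 nM to 1000000 nM.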

Compound 4, half-maximal inhibitory concentration: 432000 nM
Estimate against measurement, compound 4: 1.4-fold (0.16 log units) below, within the range that was stated.
By their numbers in this assay, from the lowest: compound 1; then compounds 2, 3 and 4 (each within the scatter of the next, the first and the last beyond it).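

In this assay, among the compounds shown here, the earlier compounds varied only the saturated chain end, so this pair is the first to show that the group on the far aromatic ring also shifts the number. With the chain end of compound 2 held fixed, hydroxy in place of trifluoromethyl gives a 2.3-fold higher number from compound 2 to compound 4 (0.37 log units; beyond the scatter), a modest step towards weaker inhibition.

Open, on these data alone, is how a methoxy group, a chlorine atom or a plain hydrogen would read at this place, and whether the same change holds with the dimethylamino chain end of compound 1. Nothing available accounts for the size or direction of this step.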